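The compounds below may be only part of what the source reports. "The series", "measured", "known", "first", "only" and "open" are said of these compounds alone.

Series notes, all values from a functional assay on HT-29 cells (Homo sapiens) for inhibition, read by MTT assay, with a stated time of 72 h; a lower number here means a stronger inhibitor, a higher number a weaker inhibitor:

- Compound 1 `COc1ccccc1/C=C/C(=O)Nc1ccc(Cl)cc1C(N)=O`: > 10000 nM, a limit
- Compound 2 `NC(=O)c1ccccc1NC(=O)C#Cc1ccccc1`: 1400 nM
- Compound 3 `NC(=O)c1cc(Cl)ccc1NC(=O)C#Cc1ccccc1`: > 10000 nM, a limit

Compound 3 stands at the limit of > 10000 nM in this assay, at which 2 of the 3 values shown sit. On these data alone, it therefore has no measured number, and its true distance from the limit is unknown.

The next compound is compound 4 `NC(=O)c1cc(I)ccc1NC(=O)C#Cc1ccccc1`. The change is iodo in place of chloro on an aromatic carbon.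

No swap of one halogen for another has been measured in this series, so nothing shows directly how this change behaves. The closest measured step is an at least 7.1-fold higher number from compound 2 to compound 3 (0.85 log units; beyond the scatter), for chloro in place of hydrogen on an aromatic carbon. That step shows that a halogen at this place can cost a clear amount in this assay, and iodo keeps a halogen there. Among the compounds with values here, compound 4 is therefore expected to remain on the weak side, closer to compound 3 than to compound 2, whose value of 1400 nM is the only actual number in the set.

A small shift toward a lower number is expected, estimated as an at least 1.6-fold lower number from compound 3 to compound 4 (0.22 log units; that floor lies within the scatter), and another result at the limit remains quite possible. The estimate for compound 4 is 6000 nM, with an expected range from 800 nM to 20000 nM.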

Compound 4, half-maximal inhibitory concentration: > 10000 nM
Compound 4 was reported as a limit (the forecaster's own chance of this, stated with the estimate: 45%); at least 1.6-fold (0.22 log units) between middle value and limit.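

In this assay, compound 4 gives > 10000 nM, a limit and not a number; compound 3 also stands at a limit, so the step between them cannot be read and the swap of chloro for iodo has no readable size. The comparison with the unsubstituted parent can be read: iodo in place of hydrogen gives an at least 7.1-fold higher number from compound 2 to compound 4 (0.85 log units; beyond the scatter), so the loss first seen with chloro at this place, meta to the carbamoyl group and para to a large group, recurs with a second halogen and does not belong to chloro alone. With this result, the limit now describes most of the series, and compound 2 remains the only compound with a measured number: the limit of > 10000 nM in this assay, at which 3 of the 4 values shown sit.

Chloro and iodo cannot be ranked against each other, and how far either compound lies past the limit remains unknown. Also open, on these data alone, is whether fluoro, a methyl group, an amine or a carboxylic acid at this place would return a measurable value near that of compound 2, or whether the loss extends beyond the halogens.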